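Swapping a dichlorophenyl for a hydroxyphenyl in compound 1

This account rests on a few compounds, and the source may have more. Where it says the series, first, only, none or still open, it means among the compounds named here.

Compound 1 `O=C1/C(=C\c2c(Cl)cccc2Cl)c2ccccc2N1c1c(Cl)cccc1Cl` gives 50 ug/mL in a functional assay on KB cells (Homo sapiens) for cytotoxicity, read by MTT assay, with a stated time of 72 h; a lower number here means that less compound is needed, a higher number that more compound is needed for the effect.
Compound 2 `O=C1/C(=C\c2cc3ccccc3nc2Cl)c2ccccc2N1c1c(Cl)cccc1Cl` gives 10 ug/mL in this assay.

Of the two measured compounds, compound 1 stands with the higher number, meaning more of it is needed for the effect; compound 2 shows a lower number, and the gap between them lies beyond the usual scatter. Compound 3 `O=C1/C(=C\c2ccc(O)cc2)c2ccccc2N1c1c(Cl)cccc1Cl` differs from compound 1 in a single place: 4-hydroxyphenyl in place of 2,6-dichlorophenyl on a double-bonded chain carbon bound to a double-bonded ring carbon. Going by the values given here, no measured pair shows this kind of change, so neither its direction nor its size can be read from the two numbers in hand. The expected step in this assay is a 1.1-fold higher number from compound 1 to compound 3 (0.04 log units; within the scatter), which would stay within the scatter of repeated measurements. On that basis the estimate for compound 3 is 55 ug/mL, with a range from 18 ug/mL to 170 ug/mL.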

Compound 3, concentration for half-maximal effect: 2 ug/mL
The estimate for compound 3 lay 28-fold (1.44 log units) above the measured number; measured number outside the range, below it.
By their numbers in this assay, from the lowest: compound 3; then compound 2; then compound 1.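

Going by these compounds alone, the position on a double-bonded chain carbon bound to a double-bonded ring carbon turns out to be highly responsive in this assay: 4-hydroxyphenyl in place of 2,6-dichlorophenyl gives a 25-fold lower number from compound 1 to compound 3 (1.40 log units; beyond the scatter), the first single-place step, and a large one. The change has two sides, since the entering group lacks the chlorine atoms of the leaving group and brings a hydrogen-bond donor and acceptor that the leaving group does not have. Nothing at hand explains the size of this step.

Within the data shown here, the single step cannot tell whether the loss of the chlorine atoms or the gain of the hydroxyl carries the effect. An unsubstituted phenyl at this place, or a methoxy group or an amine in place of the hydroxyl, would be needed to separate the two.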